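From a Bicyclic Sulfonyl Group to a Methyl

A few compounds are considered here, and "the series" means these few. Any claim that something is new, unique, unknown or untested is made for them only; others in the source may bear on it.

compound 1 `O=S(=O)(Nc1ccc2oc(-c3ccccc3)nc2c1)c1ccc(Cl)c(Cl)c1` — > 100000 nM
compound 2 `O=S(=O)(Nc1ccc2oc(-c3ccc(NS(=O)(=O)c4cccc5nonc45)cc3)nc2c1)c1ccc(Cl)s1` — 13000 nM
compound 3 `O=S(=O)(Nc1ccc2oc(-c3ccccc3)nc2c1)c1ccccc1C(F)(F)F` — > 100000 nM

Of the compounds shown here, three have been measured in an assay on cells for inhibition of HSP60/HSP10 (Homo sapiens), with a stated time of 60 min; a higher number here means a weaker inhibitor, a lower number a stronger inhibitor. Compound 1 `O=S(=O)(Nc1ccc2oc(-c3ccccc3)nc2c1)c1ccc(Cl)c(Cl)c1` reports only a limit of the assay, > 100000 nM. Compound 3 `O=S(=O)(Nc1ccc2oc(-c3ccccc3)nc2c1)c1ccccc1C(F)(F)F` likewise reports only a limit, > 100000 nM. Among the compounds with values here, compound 2 `O=S(=O)(Nc1ccc2oc(-c3ccc(NS(=O)(=O)c4cccc5nonc45)cc3)nc2c1)c1ccc(Cl)s1` is the single compound with a number, 13000 nM. Within the data shown here, compound 2 therefore stands as the only measured value, while the other two rest at the limit of > 100000 nM in this assay, at which 2 of the 3 values shown sit.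

Compound 4 `CS(=O)(=O)Nc1ccc(-c2nc3cc(NS(=O)(=O)c4ccc(Cl)s4)ccc3o2)cc1` differs from compound 2 in one place: one carbon atom in place of a group of 9 heavy atoms (6 carbon, 2 nitrogen, 1 oxygen; one five-membered aromatic ring with 3 hetero atoms, one six-membered aromatic ring of carbon only), on a sulfonyl sulfur. Among the measured compounds shown here, no step between two measured compounds is known, so the size of this change cannot be read from a comparison and can only be expected. The step from compound 2 to compound 4 is expected to move towards weaker inhibition, a 3.1-fold higher number from compound 2 to compound 4 (0.49 log units; beyond the scatter), and may run as far as the limit. Compound 4 is expected to give 40000 nM, within a range from 10000 nM to 100000 nM.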

Compound 4, half-maximal inhibitory concentration: 43000 nM
Estimate against measurement, compound 4: 1.1-fold (0.03 log units) below; the measured number falls inside the stated range.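

In this assay, within the data shown here, exchanging the bicyclic group on the sulfonyl sulfur for a methyl gives a 3.3-fold higher number from compound 2 to compound 4 (0.52 log units; beyond the scatter), the first step that can be read. The position therefore responds to this change, yet the nine heavy atoms of that group are not all needed for a measurable number, as only a modest step separates the two compounds. The step also stops short of the limit that the assay reaches elsewhere in the series: the limit of > 100000 nM in this assay, at which 2 of the 4 values shown sit.

The compounds shown leave open whether a group of intermediate size on this sulfonyl sulfur, such as an ethyl or a plain phenyl, would lie nearer compound 2 or compound 4. They also do not show how an amine or a carboxylic acid carried on the same sulfonyl group would read.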